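The compounds below may be only part of what the source reports. "The series", "measured", "known", "first", "only" and "open" are said of these compounds alone.

Two analogues sharing one amide-linked core have been measured in a functional assay on A549 cells (Homo sapiens) for cytotoxicity, read by MTT assay, with a stated time of 72 h; on this read-out lower numbers stand for stronger inhibition and higher numbers for weaker inhibition. Compound 1, `O=C(Nc1nc2ccc(Cl)cc2s1)c1cn(-c2ccccc2)nc1-c1ccc(F)cc1`, gives 3870 nM in this assay. Compound 2, `COc1ccc(-c2nn(-c3ccccc3)cc2C(=O)Nc2nc3ccccc3s2)cc1`, gives 13700 nM in this assay, the highest of the two numbers, and the nearer one, compound 1, sits lower by more than the usual scatter. Compound 1 and compound 2 differ in two places at once, so their two values alone say nothing about either change on its own.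

Compound 3, `COc1ccc(-c2nn(-c3ccccc3)cc2C(=O)Nc2nc3ccc(Cl)cc3s2)cc1`, follows from compound 2 by a single change: chloro in place of hydrogen on an aromatic carbon. Going by the values given here, no pair of measured compounds isolates this change, so the expected step is uncertain; a modest move toward a lower number is the most plausible outcome, though no shift beyond the scatter would also be unsurprising. Compound 3 is therefore expected to give about 7000 nM, within a range of 2500 nM to 20000 nM, which amounts to an estimated step of a 2.0-fold lower number from compound 2 to compound 3 (0.29 log units; within the scatter).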

Compound 3, half-maximal inhibitory concentration: 4710 nM
Beside the measured number, compound 3's estimate is 1.5-fold (0.17 log units) above it; the range from low to high includes it.
By their numbers in this assay, from the lowest: compounds 1 and 3 (each within the scatter of the next); then compound 2.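

In this assay, going from 1,3-benzothiazol-2-yl to 6-chloro-1,3-benzothiazol-2-yl while the methoxy group stays in place gives a 2.9-fold lower number from compound 2 to compound 3 (0.46 log units; beyond the scatter), so chloro in place of hydrogen on this aromatic carbon now has a step of its own, and that step lies beyond the usual scatter. With the chloro present, methoxy in place of fluoro on an aromatic carbon gives a 1.2-fold higher number from compound 1 to compound 3 (0.09 log units; within the scatter), so these two groups cannot be told apart in this setting. No measured evidence is available to explain either step.

As far as these compounds go, whether bromo, methyl or an amine on this same carbon would shift the number by more, by less or in the other direction remains open. Also open, from the compounds shown here alone, is whether chloro would give a step of similar size with fluoro in place of methoxy.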